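Swapping the halogenated ring on a shared core

The source may report more compounds than this note shows. Statements on the series, on what has been measured and on what is new or still open speak of the compounds shown alone.

Of the compounds shown here, three built on one shared core have been measured in a functional assay on NCI-H1975 cells (Homo sapiens) for cytotoxicity, read by CCK-8 assay, with a stated time of 72 h; on this read-out lower numbers stand for stronger inhibition and higher numbers for weaker inhibition. Compound 1 `C=CCn1c(=O)/c(=C\c2cccc(Cl)c2)[nH]c(=O)/c1=C\c1ccccc1OC` gives 5100 nM. Compound 2 `C=CCn1c(=O)/c(=C\c2cccc(F)c2)[nH]c(=O)/c1=C\c1ccccc1OC` gives 25600 nM, and compound 3 `C=CCn1c(=O)/c(=C\c2ccccc2Cl)[nH]c(=O)/c1=C\c1ccccc1OC` gives 9200 nM. Compound 1 therefore has the lowest of the three numbers, but its gap to compound 3 lies within the scatter, so those two cannot be ordered; only compound 2 stands clearly apart from it.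

Two measured steps start at compound 1. Fluoro in place of chloro on the aromatic carbon gave a 5.0-fold higher number from compound 1 to compound 2 (0.70 log units; beyond the scatter), a weakening. Changing to 2-chlorophenyl gave a 1.8-fold higher number from compound 1 to compound 3 (0.26 log units; within the scatter). Between those two compounds, a 2.8-fold lower number from compound 2 to compound 3 (0.44 log units; beyond the scatter).

Compound 4 `C=CCn1c(=O)/c(=C\c2cc(Br)ccc2F)[nH]c(=O)/c1=C\c1ccccc1OC` has not yet been measured. It differs from compound 1 in one place: 5-bromo-2-fluorophenyl in place of 3-chlorophenyl on a double-bonded chain carbon bound to an aromatic carbon. The new ring keeps a halogen heavier than fluorine, as in compound 1 and compound 3, and also carries a fluorine, as in compound 2, though here the fluorine is added rather than substituted for the heavier halogen. Because a 1.8-fold higher number from compound 1 to compound 3 (0.26 log units; within the scatter) was within the scatter and a 5.0-fold higher number from compound 1 to compound 2 (0.70 log units; beyond the scatter) only modest, the expected step is small, estimated as a 1.1-fold lower number from compound 1 to compound 4 (0.05 log units; within the scatter). Compound 4 is thus expected to give about 4500 nM in this assay, estimated between 1500 nM and 13000 nM.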

Compound 4, half-maximal inhibitory concentration: "not active" (no number reported)
Compound 4: no number reported, so the estimate cannot be set against anything.
By their numbers in this assay, from the lowest: compounds 1 and 3 (each within the scatter of the next); then compound 2.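

In this assay compound 4 is reported as "not active" without a number, so no step can be read between it and compound 1, compound 2 or compound 3. Nothing given here bears on this result. The compounds shown leave open which part of the 5-bromo-2-fluorophenyl ring, the bromine or the fluorine, goes with that report.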